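Replacing the lactam ring of compound 2 with a methoxylactone

A few compounds are considered here, and "the series" means these few. Any claim that something is new, unique, unknown or untested is made for them only; others in the source may bear on it.

For the measured compounds named here, compound 2 `CCC(C)CN1CC=C(CCC/C(C)=C/C=C/[C@@H](C)CC/C=C(/C)C[C@@H]2OC(=O)C(C)=C2O)C1=O` gives 6.9 ug/mL in a functional assay on SK-OV-3 cells (Homo sapiens) for cytotoxicity (a lower number here means that less compound is needed, a higher number that more compound is needed for the effect), the second highest of the three numbers known; compound 1 `CC1=C(O)[C@@H](C/C(C)=C\CC[C@H](C)/C=C/C=C(\C)CCCC2=CCN(CCC(C)C)C2=O)OC1=O` gives 4 ug/mL, within the scatter of compound 2, while compound 3 `CCC(C)CN1CC=C(CCC/C(C)=C/C=C/[C@@H](C)CC/C=C(/C)C[C@H]2OC(=O)C(C)=C2O)C1=O` gives 26.8 ug/mL. The two measured steps, a 6.7-fold higher number from compound 1 to compound 3 (0.83 log units; beyond the scatter) and a 3.9-fold higher number from compound 2 to compound 3 (0.59 log units; beyond the scatter), concern the chain carbon bound to an amide-type nitrogen in a ring and the configuration at a saturated ring carbon; neither touches the change now made. Compound 4 `COC1C=C(CCC/C(C)=C/C=C/[C@@H](C)CC/C=C(/C)C[C@@H]2OC(=O)C(C)=C2O)C(=O)O1` differs from compound 2 by a group of 8 heavy atoms (5 carbon, 3 oxygen; one five-membered non-aromatic ring with 1 hetero atom) in place of a group of 11 heavy atoms (9 carbon, 1 nitrogen, 1 oxygen; one five-membered non-aromatic ring with 1 hetero atom), on a saturated chain carbon, three bonds along the chain from a double-bonded chain carbon. Going by the values given here, no measured step bears on this exchange, so the direction remains open. Compound 4 is expected to give 10 ug/mL (range 3 ug/mL to 40 ug/mL) in this assay. This expectation means a 1.4-fold higher number from compound 2 to compound 4 (0.16 log units; within the scatter), estimated as no change beyond the scatter, with wide uncertainty.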

Compound 4, concentration for half-maximal effect: 15.2 ug/mL
For compound 4 the middle estimate is 1.5-fold (0.18 log units) below the measured one; the range from low to high includes it.
By their numbers in this assay, from the lowest: compounds 1 and 2 (each within the scatter of the next); then compounds 4 and 3 (each within the scatter of the next).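

In this assay the exchange of the group of 11 heavy atoms for the group of 8 heavy atoms, on the same saturated chain carbon, gives a 2.2-fold higher number from compound 2 to compound 4 (0.34 log units; beyond the scatter) and so costs only a modest step. Compound 4 carries no nitrogen in this group and still gives a measurable number, so that nitrogen is not needed for a read-out here. Nothing measured among these compounds accounts for the step.

The ring oxygen, the methoxy group and the loss of the nitrogen side chain all change together, and their shares stay unresolved. From the compounds shown here alone, how an amine or a carboxylic acid at this place would behave also remains open.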